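The source may hold more compounds than are shown below. What is called first, only, known or untested is meant among the compounds shown, and "the series" means these compounds.

Of the compounds shown here, three built on one shared core have been tested in an assay on isolated protein for inhibition of protein kinase C zeta type (Homo sapiens), with a stated time of 4 min, tested at 10 uM; on this read-out higher numbers stand for more inhibition at the one concentration tested (going by the name of the read-out) and lower numbers for less inhibition. Compound 1 `CC(C)(C)C1=NN(c2cccc(Cl)c2)C(c2ccc(F)c(O)c2)C1` gives 75%, compound 2 `Oc1ccc(C2CC(c3ccccc3O)=NN2c2ccc(Cl)cc2)cc1O` gives 89.7%, and compound 3 `Oc1ccc(C2CC(c3ccccc3O)=NN2c2cccc(Cl)c2)cc1F` gives 64.7%. On these numbers compound 3 stands lowest of the three: compound 1 lies above it by a gap beyond the usual scatter, and compound 2 lies higher still. Compound 4 `Oc1ccc(C2=NN(c3cccc(Cl)c3)C(c3ccc(O)c(F)c3)C2)c(O)c1` has not yet been measured. It differs from compound 3 in one place: hydroxy in place of hydrogen on an aromatic carbon. For the measured compounds named here, no pair of measured compounds differs in just this way, so there is no measured step to lean on. A modest upward step is expected, a number 7.3 percentage points higher from compound 3 to compound 4 (within the scatter), though it may not clear the scatter. Compound 4 is estimated at 72%, within 55% to 88%.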

Compound 4, a percentage reported as inhibition, at one concentration (the size of the read-out at that concentration, not a potency): 89%
Estimate against measurement, compound 4: 17 percentage points below, outside the stated range (above it).
By their numbers in this assay, from the lowest: compound 3; then compound 1; then compounds 4 and 2 (each within the scatter of the next).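

In this assay, for the compounds shown here, turning 2-hydroxyphenyl into 2,4-dihydroxyphenyl gives a number 24.3 percentage points higher from compound 3 to compound 4 (beyond the scatter) and this is the first direct reading of any single change in this set. Going by these compounds alone, a hydroxy group on this aromatic carbon, meta to a hydroxy group and para to a large group, therefore goes with more inhibition, though only this one pair shows it. No supporting data explain the rise.

On these data alone, how a methoxy group, an amine or a carboxylic acid at this carbon would compare remains open. So does whether the same step holds on other versions of the shared core.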